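Weak Amide Series: Predicting a 4-Chloro-2-methylphenyl Analogue

A few compounds are considered here, and "the series" means these few. Any claim that something is new, unique, unknown or untested is made for them only; others in the source may bear on it.

The compounds measured so far, in a functional assay on T47D cells (Homo sapiens) for antiproliferative activity, read by MTT assay, with a stated time of 72 h; a higher number here means a weaker inhibitor, a lower number a stronger inhibitor:
Compound 1, `O=C(Nc1ccc(Cl)c(-c2nnc3c(Cl)cccn23)c1)c1ccc(Cl)cc1`, gives > 100000 nM, which is a limit of the assay.
Compound 2, `O=C(Nc1ccc(Cl)c(-c2nnc3c(Cl)cccn23)c1)c1cccc(Cl)c1`, gives 30200 nM.
Compound 3, `CS(=O)(=O)c1ccc(C(=O)Nc2ccc(Cl)c(-c3nnc4c(Cl)cccn34)c2)cc1`, gives > 100000 nM, again a limit of the assay.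

Compound 3 thus stands at the limit, as noted in the limit of > 100000 nM in this assay, at which 2 of the 3 values shown sit, alongside compound 1, with only compound 2 giving a number. Compound 4, `Cc1cc(Cl)ccc1C(=O)Nc1ccc(Cl)c(-c2nnc3c(Cl)cccn23)c1`, differs from compound 3 by 4-chloro-2-methylphenyl in place of 4-(methylsulfonyl)phenyl on a carbonyl carbon.

Among the measured compounds shown here, two measured steps bear on this change. The step of an at least 3.3-fold higher number from compound 2 to compound 3 (0.51 log units; beyond the scatter) shows that the 4-(methylsulfonyl)phenyl group sits at the weak end of the set, so replacing it should not weaken compound 4 further. The step of an at least 3.3-fold lower number from compound 1 to compound 2 (0.51 log units; beyond the scatter) shows that a 4-chlorophenyl group gave a limit while a 3-chlorophenyl group gave a readable number; compound 4 carries a 4-chloro-2-methylphenyl group, closer in pattern to compound 1. He therefore expects compound 4 in this assay to land near the edge of measurability, with the step of an at least 1.6-fold lower number from compound 3 to compound 4 (0.22 log units; that floor lies within the scatter) estimated as small or unreadable. His estimate for compound 4 is 60000 nM, within the range 15000 nM to 200000 nM.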

Compound 4, half-maximal inhibitory concentration: > 100000 nM
Compound 4 ended at the assay's limit; the forecaster's own chance of this, stated with the estimate: 50%; at least 1.6-fold (0.22 log units) between middle value and limit.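

In this assay the 4-chloro-2-methylphenyl group on the carbonyl carbon brings no readable number: compound 4 gives > 100000 nM, which is a limit of the assay. Set against the 3-chlorophenyl group, the 4-chloro-2-methylphenyl group gives an at least 3.3-fold higher number from compound 2 to compound 4 (0.51 log units; beyond the scatter), so compound 2 remains the only compound here with a readable number. The steps from compound 1 and from compound 3 to compound 4 cannot be read, as both ends of each are limits, and the set now looks like this: the limit of > 100000 nM in this assay, at which 3 of the 4 values shown sit.

The compounds shown leave open whether an amine or a carboxylic acid in place of the chloro of compound 2 would keep a readable number. They also leave open whether any group on this carbonyl carbon could give a number clearly lower than that of compound 2.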